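The compounds below may be only part of what the source reports. "The series", "measured", "known", "first", "only" and "open" are said of these compounds alone.

Working notes on the series. Compound 1 `CCN1C/C(=C\c2ccc(OC)cc2)C2=NN(C(N)=S)C(c3ccc(OC)cc3)C2C1` gives 66.5% in a functional assay on Ehrlich cells (Mus musculus) for cytotoxicity, read by trypan blue exclusion, with a stated time of 24 h, tested at 50 uM; a higher number here means a stronger effect of the compound at the concentration tested, a lower number a weaker effect. Compound 2 `CCN1C/C(=C\c2ccc(OC)cc2)C2=NN(c3nc(-c4ccc(Cl)cc4)cs3)C(c3ccc(OC)cc3)C2C1` gives 100% in this assay, the highest of the three numbers shown; the step of a number 33.5 percentage points higher from compound 1 to compound 2 (beyond the scatter) is large. Compound 3 `COc1ccc(/C=C2\CN(C)CC3C2=NN(c2nc(-c4ccc(Cl)cc4)cs2)C3c2ccc(OC)cc2)cc1` gives 58%, and the step of a number 42 percentage points lower from compound 2 to compound 3 (beyond the scatter) is large in the other direction. Compound 4 `CCN1C/C(=C\c2ccc(OC)cc2)C2=NN(c3nc(-c4ccccc4)cs3)C(c3ccc(OC)cc3)C2C1` is not yet measured; it differs from compound 2 in one place: hydrogen in place of chloro on an aromatic carbon.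

Neither measured step touches this place. The step from compound 1 to compound 2 brings in the whole 4-(4-chlorophenyl)-1,3-thiazol-2-yl group at once, and the step from compound 2 to compound 3 alters the group on the amine nitrogen in the ring. Both were large, but neither separates the chloro from the rest of that group, so only a small step, possibly none beyond the scatter, is expected in this assay, and with compound 2 already at the top of the numbers any movement is expected to be downward. For compound 4 the expected value is 88%, within 65% to 100%. The expected step is a number 12 percentage points lower from compound 2 to compound 4 (beyond the scatter).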

Compound 4, a percentage reported as activity, at one concentration (the size of the read-out at that concentration, not a potency): 50.2%
For compound 4 the middle estimate is 37.8 percentage points above the measured one, and the stated range ends above it.
By their numbers in this assay, from the lowest: compounds 4, 3 and 1 (each within the scatter of the next, the first and the last beyond it); then compound 2.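

Replacing the chloro with hydrogen on this aromatic carbon, para to a large group, gives a number 49.8 percentage points lower from compound 2 to compound 4 (beyond the scatter) in this assay, so this single atom matters to the read-out in this series. The 4-phenyl-1,3-thiazol-2-yl group, placed on the amine nitrogen in the ring instead of the group of 3 heavy atoms, gives a number 16.3 percentage points lower from compound 1 to compound 4 (beyond the scatter), while the 4-(4-chlorophenyl)-1,3-thiazol-2-yl group gives a number 33.5 percentage points higher from compound 1 to compound 2 (beyond the scatter), so the direction of that exchange turns on the chloro. Nothing available explains the size of this step.

A bromo, a methyl or a carboxylic acid on the same aromatic carbon would show whether the result is specific to chloro. As far as these compounds go, it also stays open whether the chloro counts as much with the methyl on the amine nitrogen of compound 3.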